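Cyclopropyl for tert-butyl on the hydroxy-acyl side chain

The source may report more compounds than this note shows. Statements on the series, on what has been measured and on what is new or still open speak of the compounds shown alone.

Measured so far:
Compound 1, `CC(C)(C)C[C@@H](O)C(=O)N1[C@@H]2C[C@@H]2C[C@H]1C(=O)NCc1cc(Cl)ccc1-n1cnnn1`: 520 nM
Compound 2, `O=C(NCc1cc(Cl)ccc1-n1cnnn1)[C@@H]1[C@H]2C[C@H]2CN1C(=O)[C@H](O)c1ccccc1`: 960 nM
Compound 3, `CC(C)(C)C[C@@H](O)C(=O)N1[C@H](C(=O)NCc2cc(Cl)ccc2-n2cnnn2)C[C@@H]2C[C@@H]21`: 570 nM

In a functional assay on a cell-free system (plasma, Homo sapiens), with a stated time of 3 min (on this read-out lower numbers stand for stronger inhibition and higher numbers for weaker inhibition), compound 1 gives the lowest of the three numbers, but its gap to compound 3 is a 1.1-fold higher number from compound 1 to compound 3 (0.04 log units; within the scatter) and its gap to compound 2 is also within the scatter, so the three compounds cannot be ordered. Among the compounds with values here, the only measured step, from compound 1 to compound 3, rests on the fact that compounds 1 and 3 differ only in the configuration as drawn and says nothing about the side chain.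

Compound 4, `O=C(NCc1cc(Cl)ccc1-n1cnnn1)[C@@H]1C[C@H]2C[C@H]2N1C(=O)[C@H](O)CC1CC1`, differs from compound 1 by cyclopropyl in place of tert-butyl on a saturated chain carbon, two bonds along the chain from a carbonyl carbon and an oxygen on a saturated carbon. Within the data shown here, no measured pair shows this exchange, so the expectation for compound 4 rests on compound 1 alone and carries a wide range. A shorter side chain is estimated to leave the number near or somewhat above that of compound 1, a step of a 1.5-fold higher number from compound 1 to compound 4 (0.19 log units; within the scatter) in this assay. Compound 4 is therefore expected to give about 800 nM, with a range from 300 nM to 2500 nM.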

Compound 4, half-maximal inhibitory concentration: 850 nM
For compound 4 the middle estimate is 1.1-fold (0.03 log units) below the measured one; measured number inside the range.
By their numbers in this assay, from the lowest: compounds 1, 3, 4 and 2 (each within the scatter of the next).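

In this assay, the exchange of tert-butyl for cyclopropyl now has a measured pair, which gives a 1.6-fold higher number from compound 1 to compound 4 (0.21 log units; within the scatter). Within the data shown here, on a saturated chain carbon, two bonds along the chain from a carbonyl carbon and an oxygen on a saturated carbon, the neopentyl and cyclopropylmethyl side chains therefore cannot be told apart on this read-out, something that the earlier compounds, none of which carries cyclopropyl, could not show. The evidence at hand does not bear on why these two side chains read alike.

On these data alone, it remains open whether an amine, a carboxylic acid or a longer chain such as n-hexyl at this place would move the number beyond the scatter. As far as these compounds go, it also remains open whether cyclopropyl would read the same on the configuration drawn in compound 3.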